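Ring-Nitrogen Acetylation and Cytotoxicity Across Two Cores

This account rests on a few compounds, and the source may have more. Where it says the series, first, only, none or still open, it means among the compounds named here.

Compound 1 `Cc1cc(C)cc(Cn2c(=O)[nH]c3ccc(Cl)cc32)c1` gives 8900 nM in an ADME assay on MT4 cells (Homo sapiens) for cytotoxicity; a lower number here means that less compound is tolerated, a higher number that more compound is tolerated. Compound 2 `CC(=O)n1c(=O)n(Cc2cc(C)cc(C)c2)c2cc(Cl)ccc21` carries acetyl in place of hydrogen on an aromatic nitrogen and gives 7180 nM in this assay; the step is a 1.2-fold lower number from compound 1 to compound 2 (0.09 log units; within the scatter). Compound 3 `O=c1[nH]c2ccc(Cl)cc2n1Cc1cc(F)cc(F)c1` is measured only to a limit in this assay, > 424000 nM, and that limit is the one (the limit of > 424000 nM in this assay, at which 1 of the 3 values shown sits). The difference between the core of compound 1 and the core of compound 3 is not broken down here. Compound 4 `CC(=O)n1c(=O)n(Cc2cc(F)cc(F)c2)c2cc(Cl)ccc21` is not yet measured; it carries acetyl in place of hydrogen on an aromatic nitrogen, the same change as from compound 1 to compound 2, at a place described in the same words. Given the flat step a 1.2-fold lower number from compound 1 to compound 2 (0.09 log units; within the scatter), the expected step is an at least 1.2-fold lower number from compound 3 to compound 4 (0.08 log units; that floor lies within the scatter). Compound 4 is therefore expected at 350000 nM in this assay, with a real chance that only a limit is reported again.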

Compound 4, half-maximal cytotoxic concentration: 40400 nM
Compound 4: middle estimate off by 8.7-fold (0.94 log units), on the high side; measured number below the stated range.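

In this assay, acetyl in place of hydrogen on an aromatic nitrogen does not carry over at the same size from one core to the other: the same change on two cores in this assay, a 1.2-fold lower number (0.09 log units; within the scatter) from compound 1 to compound 2 and an at least 10-fold lower number (1.02 log units; beyond the scatter) from compound 3 to compound 4, at least 8.4-fold (0.92 log units) apart, beyond the scatter of two such steps. For the compounds shown here, on the core of compound 3 the result is an at least 10-fold lower number from compound 3 to compound 4 (1.02 log units; beyond the scatter), so the flat step on the core of compound 1 is no guide to the step on this core. On these data alone, compound 3 is held only at a limit, so the full size of its step stays unknown, and two cores do not show which difference between them sets the gap: the limit of > 424000 nM in this assay, at which 1 of the 4 values shown sits.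

Open, as far as these compounds go, is whether a methyl or a propanoyl group on that nitrogen would follow acetyl on either core. Also open, from the compounds shown here alone, is how acetyl behaves on a core with an amine in place of fluorine.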